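Swapping Bromo for Nitro: An Oral Rat Toxicity Estimate

A few compounds are considered here, and "the series" means these few. Any claim that something is new, unique, unknown or untested is made for them only; others in the source may bear on it.

Measured so far:
compound 1 `COc1ccc(OCC2=NCCO2)cc1`: 15%
compound 2 `Brc1ccccc1OCC1=NCCO1`: 40%

Of the compounds shown here, two have been measured in a toxicity assay on the whole organism with Rattus norvegicus as the target, at a dose of 400 mg/kg by the oral route; a higher number here means a stronger effect of the compound at the dose given, a lower number a weaker effect. Compound 1 gives 15% and compound 2 gives 40%. Compound 2 stands highest of the two numbers; its nearest neighbour is compound 1, a gap beyond the usual scatter. The two share a core but differ in more than one place, so the numbers show only what each compound gives, not a single step.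

Compound 3 `O=[N+]([O-])c1ccccc1OCC1=NCCO1` differs from compound 2 in one place: nitro in place of bromo on an aromatic carbon. Among the measured compounds shown here, no step between measured compounds covers this change, so there is no measured guide to its size. The estimate rests on compound 2 at 40%, which shares the rest of the structure. The step expected here is a number 5 percentage points lower from compound 2 to compound 3 (within the scatter), none beyond the scatter. Compound 3 is expected to give 35%, in a range from 10% to 65%.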

Compound 3, a percentage reported as activity, at one dose (the size of the read-out at that dose, not a potency): 45%
Compound 3: the middle estimate sits 10 percentage points below what was measured, within the range that was stated.
By their numbers in this assay, from the lowest: compound 1; then compounds 2 and 3 (each within the scatter of the next).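

In this assay, putting nitro in place of bromo on an aromatic carbon, ortho to a group of 7 heavy atoms, gives a number 5 percentage points higher from compound 2 to compound 3 (within the scatter). At this place on the ring, then, a group of 3 heavy atoms with 2 hydrogen-bond acceptors can replace a single bromine atom without a step that leaves the scatter, something compound 1 could not show because it differs from compound 2 in more than one place. No measurement of any property of these groups bears on this result.

As far as these compounds go, whether an amine or a carboxylic acid at this same place would also stay within the scatter of compound 2 remains open. So does whether nitro in place of bromo would give a similar step elsewhere on the ring.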